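Ester-to-acid change in the thioether series, cell tolerance

This account rests on a few compounds, and the source may have more. Where it says the series, first, only, none or still open, it means among the compounds named here.

Compound 1 `COc1nc2ccc(CSc3ccc(Cl)c(Cl)c3)cc2nc1OC` is the dichlorinated member of the series; in an ADME assay on MT4 cells (Homo sapiens) for cytotoxicity, read by MTT assay, with a stated time of 96 h (a higher number here means that more compound is tolerated, a lower number that less compound is tolerated), compound 1 gives 48000 nM. Compound 2 `CCOC(=O)c1ccc(SCc2ccc3nc(OC)c(OC)nc3c2)cc1` carries the ethyl ester instead. In this assay compound 2 reaches only the limit of the assay, > 100000 nM, which is a limit and not a number (the limit of > 100000 nM in this assay, at which 1 of the 2 values shown sits). Compound 3 `COc1nc2ccc(CSc3ccc(C(=O)O)cc3)cc2nc1OC` is still to be measured in this assay. It differs from compound 2 by hydrogen in place of ethyl on an oxygen next to a carbonyl group, in words hydrogen in place of ethyl on an oxygen next to a carbonyl group. Among the compounds with values here, no measured pair isolates this change, so the size of the step from compound 2 to compound 3 in this assay is open; no shift beyond the usual scatter is expected, and since compound 2 already sits at the limit of > 100000 nM in this assay, at which 1 of the 2 values shown sits, compound 3 is expected to stay at or near it. The estimate for compound 3 in this assay is 100000 nM, with a range of 50000 nM to 200000 nM. This corresponds to an expected step of a number no higher from compound 2 to compound 3 (the limit leaves the size open).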

Compound 3, half-maximal cytotoxic concentration: 68000 nM
The estimate for compound 3 lay 1.5-fold (0.17 log units) above the measured number; the range from low to high includes it.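

In this assay, within the data shown here, hydrogen in place of ethyl on an oxygen next to a carbonyl group gives an at least 1.4-fold lower number from compound 2 to compound 3 (0.16 log units; that floor lies within the scatter), the first step that can be read at this place. Compound 3 gives 68000 nM, so the carboxy member of the series can be read as a number. Only a floor of the step can be read, and its true size stays open, because compound 2 stands at a limit of the assay: the limit of > 100000 nM in this assay, at which 1 of the 3 values shown sits.

Going by these compounds, how a primary amide or a longer ester chain in place of ethoxycarbonyl would read in this assay stays open. Among these compounds, compound 1 differs from compound 2 and compound 3 in more than one place, so it gives no step to set beside this one.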